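A few compounds are considered here, and "the series" means these few. Any claim that something is new, unique, unknown or untested is made for them only; others in the source may bear on it.

Compound 1 `COc1ccc2c(O[C@H]3C[C@H]4C(=O)N(C)CCCC/C=C/[C@@H]5C[C@@]5(C(=O)NS(=O)(=O)C5(C)CC5)NC(=O)N4C3)cc(-c3nc(C(C)C)cs3)nc2c1Cl`: 48500 nM
Compound 2 `COc1ccc2c(O[C@H]3C[C@H]4C(=O)N(C)CCCC/C=C/[C@@H]5C[C@@]5(C(=O)NS(=O)(=O)C5(C)CC5)NC(=O)N4C3)cc(-c3csc(C(F)(F)F)n3)nc2c1Cl`: 59000 nM

In an ADME assay on Huh-7 cells (Homo sapiens) for cytotoxicity, read by colorimetric assay (a higher number here means that more compound is tolerated, a lower number that less compound is tolerated), compound 2 shows the highest of the two numbers, with compound 1 nearest at a gap within the scatter. Compound 3 `COc1ccc2c(O[C@H]3C[C@H]4C(=O)N(C)CCCC/C=C/[C@@H]5C[C@@]5(C(=O)NS(=O)(=O)C5(C)CC5)NC(=O)N4C3)cc(-n3cc(C(C)C)nn3)nc2c1Cl` differs from compound 2 by 4-isopropyl-1H-1,2,3-triazol-1-yl in place of 2-(trifluoromethyl)-1,3-thiazol-4-yl on an aromatic carbon. Among the measured compounds shown here, the only measured step on the same aromatic carbon, a 1.2-fold higher number from compound 1 to compound 2 (0.09 log units; within the scatter), stayed within the scatter, so another exchange of the group there is expected to move this assay little. Compound 3 is therefore estimated at 55000 nM, with a range of 25000 nM to 120000 nM. The expected step of a 1.1-fold lower number from compound 2 to compound 3 (0.03 log units; within the scatter) would stay within the scatter.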

Compound 3, half-maximal cytotoxic concentration: 28500 nM
For compound 3 the middle estimate is 1.9-fold (0.29 log units) above the measured one, and the stated range covers the measured number.
By their numbers in this assay, from the lowest: compounds 3, 1 and 2 (each within the scatter of the next, the first and the last beyond it).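

Exchanging the group on this aromatic carbon, next to the ring nitrogen, can move this assay beyond the scatter, though only modestly (a 2.1-fold lower number from compound 2 to compound 3 (0.32 log units; beyond the scatter)). Among the compounds shown here, the change from the isopropyl-bearing thiazole to the isopropyl-bearing triazole stays within the scatter (a 1.7-fold lower number from compound 1 to compound 3 (0.23 log units; within the scatter)), so only the pair of compounds 2 and 3 separates. Nothing available here accounts for this step.

From the compounds shown here alone, it remains open whether a triazole carrying trifluoromethyl would behave like compound 2 or compound 3. Going by these compounds, the effect of a simple amine or a phenyl ring at this carbon also remains open.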